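The source may report more compounds than this note shows. Statements on the series, on what has been measured and on what is new or still open speak of the compounds shown alone.

Compound 1 `COc1cc(-c2nnc(SCC(=O)c3ccc(Cl)cc3)n2N2C(=O)c3ccccc3C2=O)cc(OC)c1OC` gives 26600 nM in a functional assay on MKN-45 cells (Homo sapiens) for cytotoxicity, read by MTT assay, with a stated time of 48 h; on this read-out higher numbers stand for weaker inhibition and lower numbers for stronger inhibition. Compound 2 `COc1cc(-c2nnc(SC)n2N2C(=O)c3ccccc3C2=O)cc(OC)c1OC` gives only the limit > 200000 nM in this assay. Compound 3 `COc1cc(-c2nnc(SCC(=O)c3ccccc3C)n2N2C(=O)c3ccccc3C2=O)cc(OC)c1OC` likewise gives only the limit > 200000 nM in this assay.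

Compound 3 therefore stands at the limit of > 200000 nM in this assay, at which 2 of the 3 values shown sit, and no number is known for it. Compound 4 `COc1cc(-c2nnc(SCC(=O)c3ccc(F)c(F)c3)n2N2C(=O)c3ccccc3C2=O)cc(OC)c1OC` differs from compound 3 by 3,4-difluorophenyl in place of 2-methylphenyl on a carbonyl carbon. The step of an at least 7.5-fold higher number from compound 1 to compound 3 (0.87 log units; beyond the scatter) shows that the aryl group on the carbonyl carbon can move the read-out beyond the scatter, while a step that the two limits leave unreadable from compound 2 to compound 3 cannot be read. Since 3,4-difluorophenyl carries halogens as the 4-chlorophenyl of compound 1 does, compound 4 is expected to return to a measurable number, with the step of an at least 2.8-fold lower number from compound 3 to compound 4 (0.45 log units; beyond the scatter). Compound 4 is estimated at 70000 nM, within 20000 nM to 200000 nM.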

Compound 4, half-maximal inhibitory concentration: > 200000 nM
Compound 4: a limit, no number; the forecaster's own chance of this, stated with the estimate: 40%; middle value at least 2.8-fold (0.45 log units) from the limit.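

In this assay compound 4 gives only a limit, not a number: the limit of > 200000 nM in this assay, at which 3 of the 4 values shown sit. Carrying halogens on the aryl group is thus not enough to give a number, as the change to 3,4-difluorophenyl on the carbonyl carbon shows with an at least 7.5-fold higher number from compound 1 to compound 4 (0.87 log units; beyond the scatter), and of the three aryl groups shown only the 4-chlorophenyl of compound 1 gives one. The steps from compound 3 to compound 4 and from compound 2 to compound 4 cannot be read, with limits at both ends. The compounds shown leave open whether 4-bromophenyl or 4-fluorophenyl on the carbonyl carbon would give a number.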